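Moving the hydroxymethyl group along the saturated side chain

This account rests on a few compounds, and the source may have more. Where it says the series, first, only, none or still open, it means among the compounds named here.

Compound 1 `COC[C@@H](C)[C@@H](C)C(c1ccc(O)c(OC)c1)c1ccc(O)c(OC)c1` gives 85000 nM in a functional assay on HL-60 cells (Homo sapiens) for cytotoxicity, read by WST assay, with a stated time of 48 h; a higher number here means a weaker inhibitor, a lower number a stronger inhibitor.
Compound 2 `COc1cc(C(c2ccc(O)c(OC)c2)[C@H](C)[C@@H](C)CO)ccc1O` gives only a limit of this assay, > 100000 nM.

Compound 2 thus stands at the limit of this assay, and its true value is known only as lying beyond it (the limit of > 100000 nM in this assay, at which 1 of the 2 values shown sits). Among the measured compounds shown here, the one measured step that touches it, an at least 1.1-fold higher number from compound 1 to compound 2 (0.07 log units; that floor lies within the scatter), is a change in the same part of the molecule and lies within the scatter at its floor, so the two measured compounds are both weak inhibitors and cannot be ordered against each other.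

Compound 3 `COc1cc(C(c2ccc(O)c(OC)c2)[C@H](CO)C(C)C)ccc1O` has not yet been measured. It differs from compound 2 only in how the same atoms are joined: 1-(hydroxymethyl)-2-methylpropyl in place of 2-(hydroxymethyl)-1-methylpropyl on a saturated chain carbon bound to two aromatic carbons. For the measured compounds named here, no measured step shows what moving the hydroxymethyl group along this chain does, so the step from compound 1 to compound 2 is the only guide, and it was small. Compound 3 is therefore expected to show a step that the limit leaves unreadable from compound 2 to compound 3 in this assay, with a limit again the most likely outcome. Compound 3 is estimated at 110000 nM, with a range from 40000 nM to 300000 nM.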

Compound 3, half-maximal inhibitory concentration: > 100000 nM
Compound 3: no number, only a limit (the forecaster's own chance of this, stated with the estimate: 60%); the middle value lies beyond the limit too.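

Rearranging the side chain to 1-(hydroxymethyl)-2-methylpropyl, on the saturated chain carbon bound to two aromatic carbons, leaves the compound at the limit in this assay, so a second arrangement of these atoms with a free hydroxymethyl group now sits there: the limit of > 100000 nM in this assay, at which 2 of the 3 values shown sit.
Compound 2 and compound 3 are both limits, and the step between them cannot be read. Among the compounds shown here, the one readable step is an at least 1.1-fold higher number from compound 1 to compound 3 (0.07 log units; that floor lies within the scatter), so that pair cannot be ordered, and this change gives no sign of a stronger inhibitor.

Going by these compounds, what stays open is how far the true values of compound 2 and compound 3 lie beyond the limit, and so whether moving the hydroxymethyl group along the chain has any effect at all in this assay. On these data alone, it also remains open whether an amine or a carboxylic acid in place of the hydroxymethyl group, or a longer chain on the same carbon, would give a value that can be read as a number.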